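Two fluoro groups on the anilino ring, aorta inhibition

A few compounds are considered here, and "the series" means these few. Any claim that something is new, unique, unknown or untested is made for them only; others in the source may bear on it.

Measured in a functional assay (aorta) for inhibition, with Rattus norvegicus as the target; on this read-out lower numbers stand for an effect already at smaller amounts and higher numbers for an effect only at larger amounts of compound:
compound 1 `O=C1C=C(Nc2ccccc2)C(=O)c2cnccc21`: 439 nM
compound 2 `O=C1C=C(Nc2ccc(F)cc2)C(=O)c2cnccc21`: 1230 nM
compound 3 `O=C1C=C(Nc2cccc(F)c2)C(=O)c2cnccc21`: 562 nM

Compound 3 gives the second highest of the three numbers; compound 1 stands within the scatter of it, compound 2 beyond it. Compound 4 `O=C1C=C(Nc2ccc(F)c(F)c2)C(=O)c2cnccc21` is not yet measured. From compound 3 it differs by fluoro in place of hydrogen on an aromatic carbon, so compound 4 carries both fluoro groups seen in compound 2 and compound 3. For the measured compounds named here, two measured steps bear on this: a 2.8-fold higher number from compound 1 to compound 2 (0.45 log units; beyond the scatter) and a 1.3-fold higher number from compound 1 to compound 3 (0.11 log units; within the scatter). The one clearly beyond the scatter is the step that gave compound 2. A modest rise in this assay is therefore expected for compound 4, roughly a 2.5-fold higher number from compound 3 to compound 4 (0.40 log units; beyond the scatter). The estimate for compound 4 in this assay is 1400 nM, with a range of 600 nM to 3500 nM.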

Compound 4, half-maximal effective concentration: 640 nM
Beside the measured number, compound 4's estimate is 2.2-fold (0.34 log units) above it; the range from low to high includes it.
By their numbers in this assay, from the lowest: compounds 1, 3, 4 and 2 (each within the scatter of the next, the first and the last beyond it).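

In this assay, fluoro on the aromatic carbon para to a large group, here also ortho to a fluoro group, gives a 1.1-fold higher number from compound 3 to compound 4 (0.06 log units; within the scatter), so the earlier step beyond the scatter does not recur with a fluoro group already present. The same replacement leading from compound 2 to compound 4 gives a 1.9-fold lower number from compound 2 to compound 4 (0.28 log units; within the scatter), which also stays within the scatter. Even so, the two steps for the para fluoro group cannot be told apart: the same change on two cores in this assay, a 2.8-fold higher number (0.45 log units; beyond the scatter) from compound 1 to compound 2 and a 1.1-fold higher number (0.06 log units; within the scatter) from compound 3 to compound 4, 2.5-fold (0.39 log units) apart, within the scatter of two such steps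

From the compounds shown here alone, what a chloro, a methoxy or an amine would do at this position remains open.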